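The source may hold more compounds than are shown below. What is called first, only, known or untested is meant among the compounds shown, and "the series" means these compounds.

Measured so far in a functional assay on BJAB cells (Homo sapiens) for antiproliferative activity, with a stated time of 4 days; on this read-out higher numbers stand for an effect only at larger amounts of compound and lower numbers for an effect already at smaller amounts:
compound 1 `COc1ccc(C)cc1-c1c(C)nn(-c2nc(-c3ccc(Cl)c(Cl)c3)c(SC(C)C)s2)c1C(=O)O` — 9500 nM
compound 2 `Cc1nn(-c2nc(-c3ccc(Cl)c(Cl)c3)c(SC(C)C)s2)c(C(=O)O)c1Cc1ccccc1[N+](=O)[O-]` — 20000 nM

Among the measured compounds shown here, compound 2 holds the highest number of the two in this assay; compound 1 stands nearest to it, and the one measured step, a 2.1-fold higher number from compound 1 to compound 2 (0.32 log units; beyond the scatter), is the whole spread of the series so far.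

Compound 3 `Cc1nn(-c2nc(-c3ccc(Cl)c(Cl)c3)c(SC(C)C)s2)c(C(=O)O)c1-c1cncc(C#N)c1` is not yet measured. It changes compound 2 by 5-cyanopyridin-3-yl in place of 2-nitrobenzyl on an aromatic carbon. For the measured compounds named here, only one measured step bears on this: a 2.1-fold higher number from compound 1 to compound 2 (0.32 log units; beyond the scatter) also exchanged the group at this same ring carbon, and it was modest. On these data alone, neither 2-methoxy-5-methylphenyl nor 2-nitrobenzyl recurs in compound 3, so the direction of the new step cannot be read from it; 5-cyanopyridin-3-yl is untested. Compound 3 is therefore expected near 12000 nM, within a range of 4000 nM to 40000 nM, and the implied step a 1.7-fold lower number from compound 2 to compound 3 (0.22 log units; within the scatter) is expected to remain modest.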

Compound 3, half-maximal effective concentration: 20000 nM
The estimate for compound 3 lay 1.7-fold (0.22 log units) below the measured number, within the range that was stated.
By their numbers in this assay, from the lowest: compound 1; then compounds 2 and 3 (each within the scatter of the next).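

In this assay, 5-cyanopyridin-3-yl in place of 2-nitrobenzyl gives no change at the digits printed from compound 2 to compound 3 (within the scatter), so at this aromatic carbon, a ring of carbon only and a ring with a hetero atom are not told apart by this read-out. The second new step, a 2.1-fold higher number from compound 1 to compound 3 (0.32 log units; beyond the scatter), leaves compound 1 with the lowest number of the three, beyond the scatter from both others, though only by a modest margin. No measurement at hand gives a reason for either step.

Open, on these data alone, is whether an amine or a longer alkyl chain at this ring carbon would shift the number at all. Also open, as far as these compounds go, is whether the modest gap to compound 1 would survive with a methoxy group alone or a methyl group alone on the phenyl ring.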